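Oxan-4-yl in place of 2-methoxyphenyl on the amide

The source may hold more compounds than are shown below. What is called first, only, known or untested is meant among the compounds shown, and "the series" means these compounds.

Three amides on the shared core have been tested in a toxicity assay on THP-1 cells (Homo sapiens) for inhibition; on this read-out lower numbers stand for higher toxicity in this test and higher numbers for lower toxicity in this test. Compound 1 `COc1ccc(-c2cnc(NC(=O)c3ccccc3F)n2C)cc1` carries a 2-fluorophenyl on the carbonyl carbon. In this assay compound 1 gives > 100000 nM, which is a limit of the assay and not a number. Compound 2 `COc1ccc(-c2cnc(NC(=O)c3ccn[nH]3)n2C)cc1` carries a 1H-pyrazol-5-yl on the carbonyl carbon. In this assay compound 2 gives > 100000 nM, again only a limit. Compound 3 `COc1ccc(-c2cnc(NC(=O)c3ccccc3OC)n2C)cc1` carries a 2-methoxyphenyl on the carbonyl carbon. In this assay compound 3 gives > 100000 nM, also a limit. Compound 3 therefore stands at the limit of > 100000 nM in this assay, at which 3 of the 3 values shown sit. The steps a step that the two limits leave unreadable from compound 1 to compound 2, a step that the two limits leave unreadable from compound 1 to compound 3 and a step that the two limits leave unreadable from compound 2 to compound 3 cannot be read in size. Compound 4 `COc1ccc(-c2cnc(NC(=O)C3CCOCC3)n2C)cc1` has not yet been measured. It differs from compound 3 by oxan-4-yl in place of 2-methoxyphenyl on a carbonyl carbon. The measured steps bear on this change only in that every exchange of the group on the carbonyl carbon so far has left the value at the limit. The step expected in this assay is a step that the limit leaves unreadable from compound 3 to compound 4, none beyond the scatter. For compound 4 the estimate in this assay is 150000 nM, with a range from 50000 nM to 500000 nM.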

Compound 4, half-maximal cytotoxic concentration: > 100000 nM
Compound 4: a limit, no number; the forecaster's own chance of this, stated with the estimate: 85%; the middle value lies beyond the limit too.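

No step from compound 1, compound 2 or compound 3 to compound 4 can be read in this assay, since the result for compound 4 is again only a limit of the assay: the limit of > 100000 nM in this assay, at which 4 of the 4 values shown sit.

The compounds shown leave open whether any group on the carbonyl carbon gives a readable value in this assay, and how far these four amides differ.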